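Swapping 3-bromophenyl for 4-fluorophenyl on an amide-type nitrogen

The source may hold more compounds than are shown below. What is called first, only, known or untested is meant among the compounds shown, and "the series" means these compounds.

compound 1 `O=C(CCCCCCNC(=O)C(O)(O)C(F)(F)F)Nc1nc2ccccc2s1`: 2370 nM
compound 2 `O=C(CCCCCCNC(=O)C(O)(O)C(F)(F)F)Nc1cccc(Br)c1`: 3060 nM

In a functional assay on HCT-116 cells (Homo sapiens) for inhibition, read by colorimetric assay, with a stated time of 3 days (a lower number here means a stronger inhibitor, a higher number a weaker inhibitor), compound 2 gives 3060 nM and compound 1 gives 2370 nM, so the two stand level, within the scatter of each other. Compound 3 `O=C(CCCCCCNC(=O)C(O)(O)C(F)(F)F)Nc1ccc(F)cc1` carries 4-fluorophenyl in place of 3-bromophenyl on an amide-type nitrogen. Within the data shown here, one measured step bears on this change, a replacement of the group on the same nitrogen: a 1.3-fold higher number from compound 1 to compound 2 (0.11 log units; within the scatter). Among the measured compounds shown here, that single step stayed within the scatter, but it is a thin base, and no measured compound carries 4-fluorophenyl. No step beyond the scatter is therefore expected in this assay, and neither direction is favoured. The expected step is a 1.1-fold lower number from compound 2 to compound 3 (0.04 log units; within the scatter). For compound 3 the estimated value is 2800 nM, with an expected range of 1300 nM to 6000 nM.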

Compound 3, half-maximal inhibitory concentration: 7570 nM
Estimate against measurement, compound 3: 2.7-fold (0.43 log units) below, and the stated range ends below it.
By their numbers in this assay, from the lowest: compounds 1 and 2 (each within the scatter of the next); then compound 3.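

In this assay, the group on the amide-type nitrogen can move the number beyond the scatter, which the earlier pair did not show: 4-fluorophenyl gives a 2.5-fold higher number from compound 2 to compound 3 (0.39 log units; beyond the scatter) and a 3.2-fold higher number from compound 1 to compound 3 (0.50 log units; beyond the scatter), making compound 3 the weakest of the three compounds. The change from 3-bromophenyl to 4-fluorophenyl keeps the six-membered aromatic ring of carbon only, so a swap within the same kind of ring is enough to produce a modest step, even though 3-bromophenyl and 1,3-benzothiazol-2-yl stand level. No measurement offered here accounts for this step.

Compound 3 differs from compound 2 in both the halogen and its place on the ring, and these two changes cannot be separated. As far as these compounds go, how 4-bromophenyl, 3-fluorophenyl or unsubstituted phenyl would read on this nitrogen remains open.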